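Heteroaryl for fluorophenyl: outlook for compound 3

The source may hold more compounds than are shown below. What is called first, only, known or untested is meant among the compounds shown, and "the series" means these compounds.

compound 1 `COc1cc(/C=C/c2ccc(NC(=O)/C=C/c3ccc(C#N)cc3)cc2)cc(OC)c1`: 3320 nM
compound 2 `COc1cc(/C=C/c2ccc(NC(=O)/C=C/c3cccc(F)c3)cc2)cc(OC)c1`: 16800 nM

Both values come from a functional assay on HT-29 cells (Homo sapiens) for inhibition, read by MTT assay, with a stated time of 48 h; on this read-out lower numbers stand for stronger inhibition and higher numbers for weaker inhibition. For the measured compounds named here, compound 2 shows the highest number of the two; its only neighbour is compound 1, separated by the step of a 5.1-fold higher number from compound 1 to compound 2 (0.70 log units; beyond the scatter). Compound 3 `COc1cc(/C=C/c2ccc(NC(=O)/C=C/c3ccccn3)cc2)cc(OC)c1` differs from compound 2 by pyridin-2-yl in place of 3-fluorophenyl on a double-bonded chain carbon bound to a double-bonded chain carbon. Going by the values given here, no measured step exchanges a carbon-only ring for a ring with a ring nitrogen, so the single known step bears on it only loosely: it shows that swapping the ring on this chain carbon moves the number by a modest amount, without fixing a direction for the present change. Compound 3 is expected near 10000 nM, range 3000 nM to 35000 nM. That estimate means a step of a 1.7-fold lower number from compound 2 to compound 3 (0.23 log units; within the scatter), expected to lie within the scatter.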

Compound 3, half-maximal inhibitory concentration: 6120 nM
Compound 3: the middle estimate sits 1.6-fold (0.21 log units) above what was measured, and the stated range covers the measured number.
By their numbers in this assay, from the lowest: compounds 1 and 3 (each within the scatter of the next); then compound 2.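

In this assay, for the compounds shown here, the exchange of 3-fluorophenyl for pyridin-2-yl on this chain carbon gives a 2.7-fold lower number from compound 2 to compound 3 (0.44 log units; beyond the scatter), the first step here to a ring with a ring nitrogen, and it is not a loss. Exchanging 4-cyanophenyl for the same ring gives a 1.8-fold higher number from compound 1 to compound 3 (0.27 log units; within the scatter), so these two rings are not separated at this position. Nothing at hand accounts for either step. Still open, as far as these compounds go, is whether pyridin-3-yl or pyridin-4-yl would match pyridin-2-yl here, and how a phenyl ring carrying a carboxylic acid would compare.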